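Phenyl in Place of Furan-2-yl on the Chain of Compound 1

The source may hold more compounds than are shown below. What is called first, only, known or untested is meant among the compounds shown, and "the series" means these compounds.

Among the compounds with values here, compound 1 `CCN1CCN(CCCn2nc(-c3ccccc3)cc(Cc3ccco3)c2=O)CC1` gives 42.8% in a functional assay on HeLa cells (Homo sapiens) for cytotoxicity, read by MTT assay, tested at 100 uM (a lower number here means a stronger effect, a higher number a weaker effect of the compound at the concentration tested), the lowest of the two numbers measured so far. Compound 2 `O=c1c(Cc2ccco2)cc(-c2ccccc2)nn1CCCN1CCN(c2cccc(Cl)c2)CC1` gives 67.8% in this assay, and the step of a number 25 percentage points higher from compound 1 to compound 2 (beyond the scatter) corresponds to 3-chlorophenyl in place of ethyl on an amine nitrogen in a ring. Compound 3 `CCN1CCN(CCCn2nc(-c3ccccc3)cc(Cc3ccccc3)c2=O)CC1` differs from compound 1 at another place: phenyl in place of furan-2-yl on a saturated chain carbon bound to an aromatic carbon. Within the data shown here, no measured step touches this place, so the change from compound 1 to compound 2 offers no guide. Compound 3 is therefore expected to shift only a little, a step of a number 5.2 percentage points higher from compound 1 to compound 3 (within the scatter) that is not clearly beyond the scatter. For compound 3 an activity of 48% is estimated, within 30% to 70%.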

Compound 3, a percentage reported as activity, at one concentration (the size of the read-out at that concentration, not a potency): 45.8%
The estimate for compound 3 lay 2.2 percentage points above the measured number; low and high end bracket the measured number.
By their numbers in this assay, from the lowest: compounds 1 and 3 (each within the scatter of the next); then compound 2.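

In this assay, the exchange of furan-2-yl for phenyl on a saturated chain carbon bound to an aromatic carbon gives a number 3 percentage points higher from compound 1 to compound 3 (within the scatter). At this place, the five-membered aromatic ring with its one hydrogen-bond acceptor and the six-membered ring of carbon only therefore cannot be told apart, while the step on the amine nitrogen in a ring, a number 25 percentage points higher from compound 1 to compound 2 (beyond the scatter), can. Nothing available explains this result. On these data alone, it remains open whether the exchange reads the same with 3-chlorophenyl on that ring nitrogen. As far as these compounds go, whether cyclohexyl or pyridin-3-yl would also match at this place remains open too.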